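The source may hold more compounds than are shown below. What is called first, only, known or untested is meant among the compounds shown, and "the series" means these compounds.

Measured so far in a functional assay on ileum for inhibition of histamine H1 receptor (Cavia porcellus); a higher number here means a weaker inhibitor, a lower number a stronger inhibitor:
- compound 1 `CCOCCn1c(N2CCN(C)CC2)nc2ccccc21`: 10 nM
- compound 2 `CCOCCn1c(N2CCN(c3ccccc3)CC2)nc2ccccc21`: > 10000 nM
- compound 3 `CCCCN1CCN(c2nc3ccccc3n2CCOCC)CC1`: 15 nM

The value of compound 2 is a limit of this assay, not a number; compound 2 sits at the limit of > 10000 nM in this assay, at which 1 of the 3 values shown sits. Of the two numbers shown, compound 1 has the lowest; its nearest neighbour is compound 3, with a 1.5-fold higher number from compound 1 to compound 3 (0.18 log units; within the scatter), where propyl replaces hydrogen on a saturated chain carbon bound to the amine nitrogen in the ring. Within the data shown here, the only steps beyond the scatter both involve phenyl on that ring nitrogen: an at least 1000-fold higher number from compound 1 to compound 2 (3.00 log units; beyond the scatter) and an at least 660-fold lower number from compound 2 to compound 3 (2.82 log units; beyond the scatter).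

Compound 4 `CCCCOCCn1c(N2CCN(C)CC2)nc2ccccc21` differs from compound 1 by ethyl in place of hydrogen on a saturated chain carbon, two bonds along the chain from an oxygen on a saturated carbon. The change lies on the ethoxy chain, not on the ring nitrogen where the large steps occur. Among the measured compounds shown here, no measured step touches this chain; the one alkyl extension measured elsewhere, from compound 1 to compound 3, stays within the scatter. A step of similar size, within the scatter, is therefore expected: a 1.5-fold higher number from compound 1 to compound 4 (0.18 log units; within the scatter). Compound 4 is estimated at 15 nM, between 5 nM and 50 nM.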

Compound 4, half-maximal inhibitory concentration: 38 nM
Estimate against measurement, compound 4: 2.5-fold (0.40 log units) below; low and high end bracket the measured number.
By their numbers in this assay, from the lowest: compounds 1 and 3 (each within the scatter of the next); then compound 4. At a limit, above all of these: compound 2.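

In this assay, the ethoxy chain of compound 1 proves sensitive to extension: ethoxy to butoxy gives a 3.8-fold higher number from compound 1 to compound 4 (0.58 log units; beyond the scatter), a modest step but one beyond the scatter. Among these compounds, the alkyl extension on the other side of the molecule, a 1.5-fold higher number from compound 1 to compound 3 (0.18 log units; within the scatter), stays within the scatter, so a longer alkyl group does not read the same at these two places, and the one result from compound 1 cannot be carried over to the other. Nothing shown here gives a cause for the step to compound 4.

As far as these compounds go, with only ethoxy and butoxy at this position, it remains open whether the number keeps rising along a longer chain such as hexyloxy, or falls with a shorter methoxy. Also open, from the compounds shown here alone, is how a terminal amine or carboxylic acid on this chain would compare with ethoxy.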